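Adding a Third Methoxy Group to Compound 3

This account rests on a few compounds, and the source may have more. Where it says the series, first, only, none or still open, it means among the compounds named here.

Of the compounds shown here, three sharing one core have been measured in a functional assay on A549 cells (Homo sapiens) for cytotoxicity, read by MTT assay, with a stated time of 48 h; on this read-out lower numbers stand for stronger inhibition and higher numbers for weaker inhibition. Compound 1 `COc1cc(-c2cc(C(=O)Nc3nc4ccc(Cl)cc4s3)nc3cc(-c4ccccc4)nn23)cc(OC)c1OC` gives 18200 nM. Compound 2 `COc1ccc2nc(NC(=O)c3cc(-c4cc(OC)c(OC)c(OC)c4)n4nc(-c5ccccc5)cc4n3)sc2c1` gives 2810 nM, and compound 3 `COc1ccc(-c2cc(C(=O)Nc3nc4cc(C)c(C)cc4s3)nc3cc(-c4ccccc4)nn23)cc1OC` gives 2950 nM. Compound 3 thus stands second highest of the three numbers; its value and that of compound 2 lie within the scatter of each other, while compound 1 sits beyond the scatter above it. The only single-point step among these, a 6.5-fold lower number from compound 1 to compound 2 (0.81 log units; beyond the scatter), concerns a change that does not touch the group altered here.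

Compound 4 `COc1cc(-c2cc(C(=O)Nc3nc4cc(C)c(C)cc4s3)nc3cc(-c4ccccc4)nn23)cc(OC)c1OC` differs from compound 3 by methoxy in place of hydrogen on an aromatic carbon. Among the compounds with values here, no measured pair isolates this change: compound 1 carries the same three methoxy groups as compound 4 but a different substituent elsewhere, so its higher number cannot be assigned to the methoxy count alone. Within the data shown here, with no direct precedent, the change is expected to leave the number within the scatter, a 1.2-fold higher number from compound 3 to compound 4 (0.07 log units; within the scatter). Compound 4 is therefore estimated at 3500 nM, with a range from 1200 nM to 10000 nM.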

Compound 4, half-maximal inhibitory concentration: 2340 nM
Beside the measured number, compound 4's estimate is 1.5-fold (0.17 log units) above it, within the range that was stated.
By their numbers in this assay, from the lowest: compounds 4, 2 and 3 (each within the scatter of the next); then compound 1.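

In this assay, the step from 3,4-dimethoxyphenyl to 3,4,5-trimethoxyphenyl can now be read directly as a 1.3-fold lower number from compound 3 to compound 4 (0.10 log units; within the scatter) with the rest of the molecule held fixed, so the added methoxy group makes no difference beyond the scatter here. With the 3,4,5-trimethoxyphenyl group held fixed, changing only the group on the amide-type nitrogen gives a 1.2-fold lower number from compound 2 to compound 4 (0.08 log units; within the scatter) and a 7.8-fold lower number from compound 1 to compound 4 (0.89 log units; beyond the scatter), which ties the high number of compound 1 to its 6-chloro-1,3-benzothiazol-2-yl group and not to its methoxy count. No measurement here offers an explanation for these results.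

The compounds shown leave open whether the added methoxy group would behave the same way with the 6-chloro-1,3-benzothiazol-2-yl or 6-methoxy-1,3-benzothiazol-2-yl group in place. They also leave open whether an amine or a longer chain such as ethoxy on this aromatic carbon would shift the number beyond the scatter.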